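The compounds below may be only part of what the source reports. "The series", "measured", "known", "first", "only" and "open" are said of these compounds alone.

Measured so far:
- compound 1, `Fc1ccc(C(SCCNC2CCN(Cc3ccc(Cl)cc3)CC2)c2ccc(F)cc2)cc1`: 45.5 nM
- compound 2, `O=C(c1cc2ccccc2o1)N1CCC(NCCSC(c2ccc(F)cc2)c2ccc(F)cc2)CC1`: 304 nM
- compound 3, `O=C(c1cc2ccccc2[nH]1)N1CCC(NCCSC(c2ccc(F)cc2)c2ccc(F)cc2)CC1`: 1130 nM

Within this set compound 3 carries the highest number in an assay on membranes from Cortex for displacement of a labelled ligand from Sigma non-opioid intracellular receptor 1 (Cavia porcellus), read by scintillation counting, with a stated time of 120 min; a higher number here means a weaker inhibitor, a lower number a stronger inhibitor: compared with it, the step of a 3.7-fold higher number from compound 2 to compound 3 (0.57 log units; beyond the scatter) and the step of a 25-fold higher number from compound 1 to compound 3 (1.40 log units; beyond the scatter) both run upward, so compound 3 is the weakest inhibitor of the three, with compound 2 nearest and compound 1 furthest away.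

Compound 4, `CC(C)(C)CN1CCC(NCCSC(c2ccc(F)cc2)c2ccc(F)cc2)CC1`, has not been measured. Its difference from compound 3 is neopentyl in place of (1H-indol-2-yl)carbonyl on an amine nitrogen in a ring. Within the data shown here, the only measured steps that touch this position on the ring are a 6.7-fold higher number from compound 1 to compound 2 (0.82 log units; beyond the scatter) and a 25-fold higher number from compound 1 to compound 3 (1.40 log units; beyond the scatter), where a carbonyl-linked bicyclic aromatic group took the place of a benzyl group; both raised the number, the second one by a large margin. The change to compound 4 runs the other way: the carbonyl-linked group leaves and an alkyl group without a carbonyl, as in compound 1, enters. On that basis a large downward step is expected in this assay, a 19-fold lower number from compound 3 to compound 4 (1.27 log units; beyond the scatter), bringing compound 4 near the region of compound 1 rather than that of compound 2 or compound 3. Among the measured compounds shown here, since no measured compound carries neopentyl, the width of the range is kept generous. The estimate for compound 4 is 60 nM, with a range from 15 nM to 250 nM.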

Compound 4, inhibition constant: 315 nM
Compound 4: the middle estimate sits 5.3-fold (0.72 log units) below what was measured, outside the stated range (above it).
By their numbers in this assay, from the lowest: compound 1; then compounds 2 and 4 (each within the scatter of the next); then compound 3.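

In this assay, removing the carbonyl from the group on an amine nitrogen in a ring does not by itself return the number to that of compound 1: a 3.6-fold lower number from compound 3 to compound 4 (0.55 log units; beyond the scatter) is a modest step, while a 1.0-fold higher number from compound 2 to compound 4 (0.02 log units; within the scatter) places neopentyl level with (1-benzofuran-2-yl)carbonyl, so the presence of a carbonyl does not sort these four compounds. The step of a 6.9-fold higher number from compound 1 to compound 4 (0.84 log units; beyond the scatter) keeps the saturated chain carbon bound to this nitrogen and exchanges only 4-chlorophenyl for tert-butyl, showing that an alkyl group lacking a carbonyl need not match the 4-chlorobenzyl group of compound 1. No independent data bear on the reason for these differences.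

The compounds shown leave open whether the low number of compound 1 depends on the chlorine or on the aromatic ring, which an unsubstituted benzyl or a cyclohexylmethyl group on this nitrogen would separate. They also leave open whether a 4-chlorobenzoyl group would stay near compound 1 or move towards compound 2 and compound 3, a comparison that would isolate the carbonyl within the 4-chlorophenyl series.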